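The compounds below may be only part of what the source reports. "The series", "measured", "known", "first", "only" and "open" are said of these compounds alone.

Measured so far in a functional assay on A549 cells (Homo sapiens) for cytotoxicity, read by MTT assay, with a stated time of 24 h, tested at 10 uM; on this read-out lower numbers stand for a stronger effect and higher numbers for a weaker effect at the one concentration tested:
compound 1, `CCCCCCCOC(=O)CCC(=O)N1CCN(CCCOc2cc3c(Nc4ccc(F)c(Cl)c4)ncnc3cc2OC)CC1`, gives 89.1%
compound 2, `CCCCCCCCCCCCCOC(=O)CCC(=O)N1CCN(CCCOc2cc3c(Nc4ccc(F)c(Cl)c4)ncnc3cc2OC)CC1`, gives 93.7%
compound 3, `CCCCCCCCCCCCCCOC(=O)CCC(=O)N1CCN(CCCOc2cc3c(Nc4ccc(F)c(Cl)c4)ncnc3cc2OC)CC1`, gives 100%

Compound 3 holds the highest of the three numbers in this assay; its nearest neighbour is compound 2, with the step of a number 6.3 percentage points higher from compound 2 to compound 3 (within the scatter), and the furthest is compound 1, with the step of a number 10.9 percentage points higher from compound 1 to compound 3 (beyond the scatter). The remaining step, a number 4.6 percentage points higher from compound 1 to compound 2 (within the scatter), is likewise small. Compound 4, `CCCCCCCCCCCCCCCCCOC(=O)CCC(=O)N1CCN(CCCOc2cc3c(Nc4ccc(F)c(Cl)c4)ncnc3cc2OC)CC1`, differs from compound 3 by propyl in place of hydrogen on a saturated chain carbon, ten or more bonds along the chain from an oxygen next to a carbonyl group. The step that bears most directly on it is a number 6.3 percentage points higher from compound 2 to compound 3 (within the scatter), the same kind of lengthening at the same kind of place; a number 4.6 percentage points higher from compound 1 to compound 2 (within the scatter) and a number 10.9 percentage points higher from compound 1 to compound 3 (beyond the scatter) also lengthen the chain, and only the largest of the three steps lies beyond the scatter. The numbers already sit near the top of the scale in this assay, so no step beyond the scatter is expected from compound 3 to compound 4, the expected step being a number 1 percentage points lower from compound 3 to compound 4 (within the scatter). Compound 4 is therefore estimated at 99% in this assay, with a range from 88% to 110%.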

Compound 4, a percentage reported as activity, at one concentration (the size of the read-out at that concentration, not a potency): 95.7%
Estimate against measurement, compound 4: 3.3 percentage points above; low and high end bracket the measured number.
By their numbers in this assay, from the lowest: compounds 1, 2, 4 and 3 (each within the scatter of the next, the first and the last beyond it).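

In this assay, propyl in place of hydrogen on a saturated chain carbon, ten or more bonds along the chain from an oxygen next to a carbonyl group, gives a number 4.3 percentage points lower from compound 3 to compound 4 (within the scatter), and butyl at that place gives a number 2 percentage points higher from compound 2 to compound 4 (within the scatter). The only step beyond the scatter in the series remains a number 10.9 percentage points higher from compound 1 to compound 3 (beyond the scatter); decyl, seven bonds along the chain, gives a number 6.6 percentage points higher from compound 1 to compound 4 (within the scatter), so the longest chain shown does not repeat that separation from compound 1. Nothing available here explains these numbers.

All four compounds carry an unbranched saturated chain at this place and read near the top of the scale. Open, as far as these compounds go, is whether an amine or a carboxylic acid at the chain end, or a much shorter chain such as methyl, would stand beyond the scatter from compound 1.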